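From a Ring Amide to an Open-Chain Amide

The source may report more compounds than this note shows. Statements on the series, on what has been measured and on what is new or still open speak of the compounds shown alone.

Of the compounds shown here, two have so far been tested in an ADME assay on HepG2 cells (Homo sapiens) for cytotoxicity, read by CellTiter-Glo and ATP content, with a stated time of 72 h; on this read-out lower numbers stand for an effect already at smaller amounts and higher numbers for an effect only at larger amounts of compound. Compound 1 `CN(Cc1cccc(F)c1)C(=O)CN(C)C(=O)c1ccc(S(C)(=O)=O)c([N+](=O)[O-])c1` reached only the limit of the assay there, > 27000 nM. For the measured compounds named here, compound 2 `CS(=O)(=O)c1ccc(C(=O)NCC(=O)N2CCCCC2)cc1[N+](=O)[O-]` gives 14000 nM, the only actual number in this set. Compound 3 `CC(C)N(C(=O)CNC(=O)c1ccc(S(C)(=O)=O)c([N+](=O)[O-])c1)C(C)C` differs from compound 2 in one place: diisopropylamino in place of piperidin-1-yl on a carbonyl carbon. Going by the values given here, no measured pair shows what such a swap does here, so no shift beyond the usual scatter is expected: a 1.1-fold higher number from compound 2 to compound 3 (0.03 log units; within the scatter). Compound 3 is therefore estimated at 15000 nM, with a likely range from 6000 nM to 40000 nM.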

Compound 3, half-maximal effective concentration: > 27000 nM
Compound 3 was reported as a limit (the forecaster's own chance of this, stated with the estimate: 40%); middle value at least 1.8-fold (0.25 log units) from the limit.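

For the compounds shown here, replacing the piperidin-1-yl ring with the open-chain diisopropylamino group on this carbonyl carbon gives the only step measured at this position: an at least 1.9-fold higher number from compound 2 to compound 3 (0.28 log units; that floor lies within the scatter). Compound 3 gives > 27000 nM, which is a limit of the assay and not a number. The swap therefore brings no lower number, but its true size cannot be read, since the values stop at the same ceiling: the limit of > 27000 nM in this assay, at which 2 of the 3 values shown sit.

Still open, from the compounds shown here alone, is how a smaller open-chain group such as dimethylamino would read here. Going by these compounds, a ring with an added oxygen, such as morpholin-4-yl, is equally open.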